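This account rests on a few compounds, and the source may have more. Where it says the series, first, only, none or still open, it means among the compounds named here.

Series notes. Compound 1 `O=C(Nc1cccnc1)c1ccccc1Cl` is the simplest member; in an assay on cells for inhibition of cytochrome P450 11B2, mitochondrial (Homo sapiens), read by HTRF (on this read-out lower numbers stand for stronger inhibition and higher numbers for weaker inhibition), compound 1 gives 967 nM. Compound 2 `CC(=O)N[C@H]1CCCc2c1cncc2N1Cc2cc(Cl)ccc2C1=O` carries an acetamide on the shared core; in this assay compound 2 gives 5140 nM. Compound 3 `CCS(=O)(=O)N[C@@H]1CCCc2c1cncc2N1Cc2cc(Cl)ccc2C1=O` carries an ethylsulfonamide in place of that acetamide; in this assay compound 3 gives 40 nM, the lowest of the three numbers, and its distance to compound 1 as well as to compound 2 lies beyond the usual scatter. Among the measured compounds shown here, no two measured compounds differ in a single place, so no measured step can be carried over to a new change.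

Compound 4 `CS(=O)(=O)N[C@@H]1CCCc2c1cncc2N1Cc2cc(Cl)ccc2C1=O` differs from compound 3 only in the sulfonamide: hydrogen in place of methyl on a saturated chain carbon bound to a sulfonyl sulfur, ethylsulfonyl to methylsulfonyl, (ethylsulfonyl)amino to methanesulfonamido. Nothing measured here shows what shortening this chain does. Since the sulfonyl group and the rest of the molecule stay the same, the step of a 1.5-fold higher number from compound 3 to compound 4 (0.18 log units; within the scatter) is expected to be small, within or close to the scatter, if anything towards a somewhat higher number. Compound 4 is therefore expected at 60 nM, with a range from 20 nM to 180 nM. Whether the sulfonyl group or the chain length accounts for what compound 2 and compound 3 show cannot be separated with compounds 1 to 3 alone.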

Compound 4, half-maximal inhibitory concentration: 998 nM
Compound 4: middle estimate off by 17-fold (1.22 log units), on the low side; measured number above the stated range.
By their numbers in this assay, from the lowest: compound 3; then compounds 1 and 4 (each within the scatter of the next); then compound 2.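

In this assay, among the compounds shown here, the change from ethylsulfonyl to methylsulfonyl gives the first single-place comparison, a large step: a 25-fold higher number from compound 3 to compound 4 (1.40 log units; beyond the scatter). This position on the sulfonamide is therefore sensitive to the loss of one methyl on a saturated chain carbon bound to a sulfonyl sulfur, even though the sulfonyl group and the rest of the molecule stay the same. The sulfonyl group alone thus does not secure the number of compound 3 (40 nM), since compound 4 retains it, and nothing available explains why this single methyl matters so much.

The compounds shown give only two chain lengths on the sulfonyl group, so it remains open whether a longer chain such as propyl, a branched isopropyl or a cyclopropyl ring would continue, hold or reverse this step. Also open, on these data alone, is whether the ethyl group itself is what counts at this place, or whether a similar chain carrying an ether oxygen or a terminal fluorine would serve equally well.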